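Amide swap on a shared core, tracked in a cytotoxicity test

The compounds below may be only part of what the source reports. "The series", "measured", "known", "first", "only" and "open" are said of these compounds alone.

Measured compounds:
Compound 1, `Cc1ccccc1C(=O)Nc1ncc(-c2ccccc2)n1C`, gives > 100000 nM in a toxicity assay on THP-1 cells (Homo sapiens) for inhibition; on this read-out lower numbers stand for higher toxicity in this test and higher numbers for lower toxicity in this test.
Compound 2, `COc1ccc(-c2cnc(NC(=O)c3cccnc3)n2C)cc1`, gives > 100000 nM in this assay.
Compound 3, `Cn1c(-c2ccc(F)cc2)cnc1NC(=O)c1ccc(F)cc1`, gives > 100000 nM in this assay.

Each of these three readings is a limit of the test rather than a number. Compound 2 therefore stands at the same limit as the other two measured compounds, and nothing here separates any of them: the limit of > 100000 nM in this assay, at which 3 of the 3 values shown sit. Compound 4, `COc1ccc(-c2cnc(NC(=O)c3ccc(C#N)cc3)n2C)cc1`, has not yet been measured. It differs from compound 2 in one place: 4-cyanophenyl in place of pyridin-3-yl on a carbonyl carbon.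

Within the data shown here, no measured step stands between two compounds that differ in one place, so there is no directly comparable change to lean on. Given that compound 2 sits at a limit > 100000 nM, and that every measured compound shares that outcome, the expected step of a number no higher from compound 2 to compound 4 (the limit leaves the size open) is none beyond the scatter. Compound 4 is expected to give about 100000 nM, within 40000 nM to 250000 nM, most likely again reported only as a limit.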

Compound 4, half-maximal cytotoxic concentration: > 100000 nM
Compound 4 gave a limit, no number (the forecaster's own chance of this, stated with the estimate: 80%); the middle value sits exactly at the limit.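

In this assay compound 4 gives > 100000 nM, which is a limit and not a number. Compound 2 also stands at a limit, so no step can be read between compound 2 and compound 4: the limit of > 100000 nM in this assay, at which 4 of the 4 values shown sit.

The compounds shown leave open whether any amide swap on the shared core changes the result in this assay.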